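This account rests on a few compounds, and the source may have more. Where it says the series, first, only, none or still open, it means among the compounds named here.

Compound 1 `COc1ccc(N(C)c2nc(C)nc3ccccc23)cc1OCCC[Se]C#N`: 799 nM
Compound 2 `COc1ccc(N(C)c2nc(C)nc3ccccc23)cc1C(=O)OCCCC[Se]C#N`: 1020 nM

In a functional assay on RKO cells (Homo sapiens) for inhibition, read by MTT assay, with a stated time of 48 h (on this read-out lower numbers stand for stronger inhibition and higher numbers for weaker inhibition), compound 2 at 1020 nM lies within the scatter of compound 1, so neither stands apart. Compound 3 `COc1ccc(N(C)c2nc(C)nc3ccccc23)cc1C[Se]C#N` differs from compound 2 as follows: a group of 4 heavy atoms (2 carbon, 1 nitrogen, 1 selenium; no ring) in place of a group of 10 heavy atoms (6 carbon, 1 nitrogen, 2 oxygen, 1 selenium; no ring), on an aromatic carbon. Within the data shown here, only one measured step bears on this change, a 1.3-fold higher number from compound 1 to compound 2 (0.11 log units; within the scatter), which also swapped one group on an aromatic carbon for another of a different size. That single step is thin evidence, but it gives no reason to expect a change beyond the scatter in this assay. The expected step is a 1.3-fold lower number from compound 2 to compound 3 (0.11 log units; within the scatter). For compound 3 the estimated value is 800 nM, with an expected range from 250 nM to 2500 nM.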

Compound 3, half-maximal inhibitory concentration: 316 nM
For compound 3 the middle estimate is 2.5-fold (0.40 log units) above the measured one; measured number inside the range.
By their numbers in this assay, from the lowest: compound 3; then compounds 1 and 2 (each within the scatter of the next).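

In this assay the group on this aromatic carbon now makes a difference: a 3.2-fold lower number from compound 2 to compound 3 (0.51 log units; beyond the scatter) and a 2.5-fold lower number from compound 1 to compound 3 (0.40 log units; beyond the scatter) are both modest but beyond the scatter, whereas the step between the two larger groups stayed within it. Of the three groups, the one of 4 heavy atoms is the smallest and gives the lowest number.

From the compounds shown here alone, three compounds cannot show whether size alone counts, and how an amine or a carboxylic acid at this position would compare stays open. Nothing measured in this set explains why the number falls.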